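The compounds below may be only part of what the source reports. "The series", "measured", "known", "first", "only" and "open" are said of these compounds alone.

Compound 1 `O=[N+]([O-])c1ccc(NC(=S)N2CCN(S(=O)(=O)c3sccc3-c3ccccc3Oc3ccc(O)c(O)c3)CC2)cc1` was tested in a functional assay on HL-60 cells (Homo sapiens) for inhibition, read by CCK-8 assay, with a stated time of 48 h (on this read-out lower numbers stand for stronger inhibition and higher numbers for weaker inhibition), where compound 1 gives 5300 nM. Of the two numbers measured, compound 1 holds one; compound 3 `COc1ccc(Oc2ccc(C(C)C)cc2-c2ccsc2S(=O)(=O)NCCNC(=O)Nc2cc(C(F)(F)F)cc(C(F)(F)F)c2)cc1OC` gives 7400 nM, and the gap between these two lies within the usual scatter, so neither compound can be called the more potent. Compound 2 `O=[N+]([O-])c1cccc(NC(=S)NCCNS(=O)(=O)c2ccc(-c3ccccc3OCc3ccccc3)s2)c1` gives > 50000 nM, which is a limit of the assay and not a number (the limit of > 50000 nM in this assay, at which 1 of the 3 values shown sits). Compound 4 `O=S(=O)(c1sccc1-c1ccccc1Oc1ccc(O)c(O)c1)N1CCN(C(=S)Nc2ccc(Cl)cc2)CC1` differs from compound 1 by chloro in place of nitro on an aromatic carbon. Going by the values given here, no measured pair isolates this change, so in this assay no step beyond the scatter is expected in either direction. Compound 4 is estimated at 7000 nM, in a range from 2500 nM to 20000 nM. The step expected is a 1.3-fold higher number from compound 1 to compound 4 (0.12 log units; within the scatter).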

Compound 4, half-maximal inhibitory concentration: 5500 nM
Compound 4: middle estimate off by 1.3-fold (0.10 log units), on the high side; low and high end bracket the measured number.
By their numbers in this assay, from the lowest: compounds 1, 4 and 3 (each within the scatter of the next). At a limit, above all of these: compound 2.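

Going by these compounds alone, with chloro in place of nitro on this aromatic carbon, the read-out shows a 1.0-fold higher number from compound 1 to compound 4 (0.02 log units; within the scatter) in this assay, the first direct comparison at this position. Here the two groups cannot be told apart, although the chloro brings fewer heavy atoms and no hydrogen-bond acceptors. Nothing measured on these compounds offers a reason for this result.

Going by these compounds, whether an amine or a carboxylic acid at the same place would give a similar number remains open. So does whether a bare phenyl ring, with no group there at all, would do the same.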